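This account rests on a few compounds, and the source may have more. Where it says the series, first, only, none or still open, it means among the compounds named here.

Series notes. Compound 2 `CC(C(=O)NCc1ccc(C(F)(F)F)cc1-c1cccc(Cl)c1)c1ccc(NS(C)(=O)=O)c(F)c1` in an assay on CHO cells for antagonist activity at transient receptor potential cation channel subfamily V member 1 (Homo sapiens), read by FLIPR (a higher number here means a weaker inhibitor, a lower number a stronger inhibitor), gives 1 nM. Within the data shown here, only one other number exists in this assay, that of compound 1 `CC(C(=O)NCc1ccc(C(F)(F)F)cc1OC1CCCC1)c1ccc(NS(C)(=O)=O)c(F)c1`, which gives 0.6 nM; the two lie within the scatter of each other. Among the measured compounds shown here, the single measured step, a 1.7-fold higher number from compound 1 to compound 2 (0.22 log units; within the scatter), puts a 3-chlorophenyl where a cyclopentyloxy had been and did not move the number beyond the scatter.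

Compound 3 `CC(C(=O)NCc1ccc(C(F)(F)F)cc1-c1cccnc1)c1ccc(NS(C)(=O)=O)c(F)c1` is not yet measured. Its change from compound 2 is pyridin-3-yl in place of 3-chlorophenyl on an aromatic carbon. For the measured compounds named here, no measured step exchanges one aromatic ring for another at this position, so the step from compound 1 to compound 2 bears on it only as a sign that this position has so far accepted a change without a shift beyond the scatter; the size of a move to pyridin-3-yl is unknown. A number near that of compound 2 is expected, with a band wider than the scatter alone. For compound 3 the estimate in this assay is 3 nM, between 0.8 nM and 12 nM. The expected step is a 3.0-fold higher number from compound 2 to compound 3 (0.48 log units; beyond the scatter).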

Compound 3, inhibition constant: 59.4 nM
For compound 3 the middle estimate is 20-fold (1.30 log units) below the measured one; measured number above the stated range.
By their numbers in this assay, from the lowest: compounds 1 and 2 (each within the scatter of the next); then compound 3.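

Aromatic groups are not interchangeable at this position in this assay: replacing 3-chlorophenyl with pyridin-3-yl gives a 59-fold higher number from compound 2 to compound 3 (1.77 log units; beyond the scatter), the first step in the series beyond the scatter. Set against cyclopentyloxy, the same group gives a 99-fold higher number from compound 1 to compound 3 (2.00 log units; beyond the scatter), so the agreement within the scatter between compound 1 and compound 2 does not extend to every group placed on this aromatic carbon. Among these compounds, nothing measured so far explains the size of these steps.

The change removes the chlorine and brings in a ring nitrogen in one step, and the compounds shown do not separate the two; an unsubstituted phenyl or a chloropyridinyl group here would do so. From the compounds shown here alone, how pyridin-2-yl or pyridin-4-yl would read in this assay also remains open.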